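Moving a Bromine Around the Phenol Ring

The source may hold more compounds than are shown below. What is called first, only, known or untested is meant among the compounds shown, and "the series" means these compounds.

Compound 1 `C=CCOc1cc(Br)ccc1C(=O)c1cccnc1`: the limit > 100000 nM in a functional assay on PC-3 cells (Homo sapiens) for cytotoxicity, read by sulforhodamine B assay, with a stated time of 48 h; a higher number here means a weaker inhibitor, a lower number a stronger inhibitor
Compound 2 `O=C(c1cccnc1)c1ccccc1O`: 33400 nM
Compound 3 `O=C(c1cccnc1)c1cc(Br)ccc1O`: 60200 nM

Of the compounds shown here, three have been measured so far. Compound 1 reaches only the limit of this assay, (the limit of > 100000 nM in this assay, at which 1 of the 3 values shown sits), and gives no number. Compound 2 holds the lowest of the two numbers given, and its nearest neighbour is compound 3, which differs by a 1.8-fold higher number from compound 2 to compound 3 (0.26 log units; within the scatter); that step is within the scatter, so the two compounds cannot be told apart here.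

Compound 4 `O=C(c1cccnc1)c1ccc(Br)cc1O` has not yet been measured. It is made from compound 2 by the change (bromo in place of hydrogen on an aromatic carbon). For the measured compounds named here, the only measured step that bears on this change is the one from compound 2 to compound 3, where the same bromo enters the same ring at another place, and that step stayed within the scatter. Compound 4 is therefore expected to give a number close to that of compound 2, with at most a small rise, an expected step of a 1.5-fold higher number from compound 2 to compound 4 (0.18 log units; within the scatter). The estimate for compound 4 in this assay is 50000 nM, with a range from 20000 nM to 120000 nM.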

Compound 4, half-maximal inhibitory concentration: 88600 nM
Estimate against measurement, compound 4: 1.8-fold (0.25 log units) below; low and high end bracket the measured number.
By their numbers in this assay, from the lowest: compounds 2, 3 and 4 (each within the scatter of the next, the first and the last beyond it). At a limit, above all of these: compound 1.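

In this assay, bromo in place of hydrogen on an aromatic carbon now gives a step that passes the scatter, a 2.7-fold higher number from compound 2 to compound 4 (0.42 log units; beyond the scatter), though a modest one, whereas the same change at the other place gave only a 1.8-fold higher number from compound 2 to compound 3 (0.26 log units; within the scatter). So at this place, meta to a hydroxy group and para to a group of 8 heavy atoms, the change does lift the number, yet compounds 3 and 4 lie within the scatter of each other and the two places cannot be told apart. Hydrogen in place of allyl on the oxygen gives an at least 1.1-fold lower number from compound 1 to compound 4 (0.05 log units; that floor lies within the scatter), and this step says little about the allyl group, since compound 1 stands at a limit: the limit of > 100000 nM in this assay, at which 1 of the 4 values shown sits.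

The compounds shown leave open whether the rise belongs to bromo itself or would also follow with another group at this place, such as an amine or a carboxylic acid. They also leave open how a methyl group or a longer chain on the oxygen would read with bromo at this same place.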